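Removing the Isobutyl from a Sulfonamide Nitrogen

The source may report more compounds than this note shows. Statements on the series, on what has been measured and on what is new or still open speak of the compounds shown alone.

Among the compounds with values here, compound 1 `CCC1C(=O)N(C)c2cnc(Nc3ccc(S(=O)(=O)NCC(C)C)cc3)nc2N1c1ccn(C)n1` holds the higher of the two numbers measured so far in a functional assay on HeLa cells (Homo sapiens) for antiproliferative activity, read by CCK-8 assay, with a stated time of 72 h (on this read-out higher numbers stand for weaker inhibition of growth and lower numbers for stronger inhibition of growth), where compound 1 gives 5310 nM. Compound 2 `CC[C@@H]1C(=O)N(C)c2cnc(-n3ccc4cc(C(=O)NCC(C)C)ccc43)nc2N1C1CCCC1`, built on the same core with other substituents, gives 3280 nM in this assay; the two values lie within the usual scatter of each other, so the numbers alone do not separate them. Compound 3 `CCC1C(=O)N(C)c2cnc(Nc3ccc(S(N)(=O)=O)cc3)nc2N1c1ccn(C)n1` has not yet been measured. It differs from compound 1 in one place: hydrogen in place of isobutyl on a sulfonamide nitrogen. Within the data shown here, no pair of measured compounds differing at a single site is available, so the size of such a step cannot be read from the data. The expectation for compound 3 is a step of a 1.3-fold higher number from compound 1 to compound 3 (0.12 log units; within the scatter), meaning little change beyond the scatter. Compound 3 is thus estimated at 7000 nM in this assay, within a range from 2000 nM to 25000 nM.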

Compound 3, concentration for 50% growth inhibition: 12600 nM
For compound 3 the middle estimate is 1.8-fold (0.26 log units) below the measured one; the range from low to high includes it.
By their numbers in this assay, from the lowest: compounds 2 and 1 (each within the scatter of the next); then compound 3.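

In this assay, within the data shown here, this is the first step at a single site, and it shows that the isobutyl on the sulfonamide nitrogen is not a silent part of compound 1: a 2.4-fold higher number from compound 1 to compound 3 (0.38 log units; beyond the scatter). This nitrogen is therefore a place where the substituent registers in the read-out, and within this pair the sulfamoyl group goes with weaker inhibition of growth than the isobutylsulfamoyl group. Nothing available bears on the origin of this step.

With only isobutyl and hydrogen at this nitrogen, the compounds shown leave open how a methyl, a longer chain, a cyclopropyl or a chain ending in an amine or a carboxylic acid would read there. They also leave open whether the same step would appear with other groups elsewhere on the shared core.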